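The compounds below may be only part of what the source reports. "The series", "measured", "known", "first", "only" and "open" are said of these compounds alone.

Measured compounds:

Compound 1, `CCOC(=O)/C(C#N)=C/c1ccc(O)c(O)c1`: 57.8%
Compound 2, `N#C/C(=C\c1ccc(O)c(O)c1)C(=O)OC1CCCCC1`: 55.3%
Compound 3, `CCOC(=O)/C(C#N)=C/c1ccc[nH]1`: 25.8%

All three were tested in a functional assay on the whole organism (strain CD1) for inhibition, with Mus musculus as the target, with stated times of 15 min and 20 min, at a dose of 10 mg/kg by the subcutaneous route; on this read-out higher numbers stand for more inhibition at the one dose given (going by the name of the read-out) and lower numbers for less inhibition. Compound 1 and compound 2 share one core and differ in a single spot: cyclohexyl in place of ethyl on an oxygen next to a carbonyl group. The effect of this swap on the read-out was a number 2.5 percentage points lower from compound 1 to compound 2 (within the scatter), so the two compounds cannot be told apart on this measure.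

Compound 3 carries a different core. The difference between the two cores is not broken down here. In this assay compound 3 gives 25.8%, which is lower than the readings of compound 1 and compound 2, and both gaps are beyond the scatter.

Compound 4, `N#C/C(=C\c1ccc[nH]1)C(=O)OC1CCCCC1`, has not yet been measured. It stands to compound 3 as compound 2 stands to compound 1: cyclohexyl in place of ethyl on an oxygen next to a carbonyl group. The place of the swap is described in the same words in both pairs, so this is the same change made on another core. Since the change from compound 1 to compound 2 produced only a number 2.5 percentage points lower from compound 1 to compound 2 (within the scatter), the expectation for the step from compound 3 to compound 4 is likewise small, estimated as a number 1.8 percentage points lower from compound 3 to compound 4 (within the scatter). Whether the change behaves alike on a different core is not shown by the compounds measured so far, so the estimate carries a wide margin. Compound 4 is therefore expected to give roughly 24% in this assay, most likely between 10% and 40%.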

Compound 4, a percentage reported as inhibition, in the whole organism at one dose (the size of the read-out at that dose, not a potency): 10%
Estimate against measurement, compound 4: 14 percentage points above, within the range that was stated.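

In this assay cyclohexyl in place of ethyl on an oxygen next to a carbonyl group gives a number 15.8 percentage points lower from compound 3 to compound 4 (beyond the scatter) on the second core, and when this step is set beside the one on the first core, the two cannot be told apart: the same change on two cores in this assay, a number 2.5 percentage points lower (within the scatter) from compound 1 to compound 2 and a number 15.8 percentage points lower (beyond the scatter) from compound 3 to compound 4, 13.3 percentage points apart, within the scatter of two such steps. So the two pairs give no firm sign that the core alters what this swap does, even though only the newer step lies beyond the scatter when taken alone. They do not prove that the swap acts the same way on both cores either, as two pairs tested at a single dose can neither confirm a shared effect nor rule out a real difference hidden within the scatter.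

The compounds shown leave open how other groups on this oxygen would behave on either core, such as a longer chain like butyl or a benzyl group. They also leave open what would happen to the reading if the ester gave way to a carboxylic acid or an amide, with the rest of each core kept the same.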